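Methyl added to the shared core: expected potency shift

This account rests on a few compounds, and the source may have more. Where it says the series, first, only, none or still open, it means among the compounds named here.

Measured compounds:
compound 1 `CCOC(=O)CC[C@H](NC(=O)c1ccc(CNc2ccc3nc(N)nc(N)c3c2)cc1)C(=O)OCC`: 7.54
compound 2 `Nc1nc(O)c2c(Cl)cccc2n1`: 4.66

In an assay for inhibition of Dihydrofolate reductase (Homo sapiens) (on this read-out lower numbers stand for lower potency and higher numbers for higher potency (the scale is a negative logarithm)), compound 1 gives 7.54, the highest of the two numbers. For the measured compounds named here, compound 2 gives 4.66, a gap beyond the usual scatter, yet the two structures differ in more than one place and no single step between them is known. Compound 3 `CCOC(=O)CC[C@H](NC(=O)c1ccc(CNc2ccc3nc(N)nc(N)c3c2C)cc1)C(=O)OCC` is compound 1 with methyl in place of hydrogen on an aromatic carbon. Going by the values given here, no measured pair maps this change, so the expectation rests on compound 1 alone. The expected step is a number 0.36 log units higher from compound 1 to compound 3 (beyond the scatter), a modest gain beyond the scatter. For compound 3 the estimate in this assay is 7.9, within 7.2 to 8.6.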

Compound 3, logarithm of the reciprocal of the active concentration, log(1/C): 7.7
Estimate against measurement, compound 3: 0.20 log units above; the measured number falls inside the stated range.
By their numbers in this assay, from the lowest: compound 2; then compounds 1 and 3 (each within the scatter of the next).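

In this assay, methyl in place of hydrogen on an aromatic carbon gives a number 0.16 log units higher from compound 1 to compound 3 (within the scatter), so a methyl is accepted at this position, ortho to a fused ring and ortho to a large group, without a shift beyond the scatter. For the compounds shown here, this single step is the first reading of any one-place change. No supporting measurement bears on the reason for this result.

Still open, on these data alone, is how an ethyl group, an amine or a carboxylic acid would read at this position. As far as these compounds go, the effect of methyl on the other aromatic carbons of the shared core also remains open.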